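The source may report more compounds than this note shows. Statements on the series, on what has been measured and on what is new or still open speak of the compounds shown alone.

Measured so far:
compound 1, `CCCCCCCCCCCCCCCCCCNC(=O)[C@H]1CSC(c2cccnc2)N1`: 2900 nM
compound 2, `CCCCCCCCCCCCCCCCCCNC(=O)[C@H]1CSC(c2ccc(Br)cc2)N1`: 3700 nM

In a functional assay on PPC-1 cells (Homo sapiens) for antiproliferative activity, read by sulforhodamine B assay (a lower number here means a stronger inhibitor, a higher number a weaker inhibitor), compound 1 gives 2900 nM. Compound 2 gives 3700 nM, the larger of the two numbers shown, but only by a margin that lies within the scatter, a 1.3-fold higher number from compound 1 to compound 2 (0.11 log units; within the scatter), so the two cannot be told apart. Compound 3, `CCCCCCCCCCCCCCCCCCNC(=O)[C@H]1CSC(c2cc(F)cc(F)c2)N1`, has not yet been measured. It differs from compound 2 in one place: 3,5-difluorophenyl in place of 4-bromophenyl on a saturated ring carbon. Going by the values given here, the one measured step that bears on this change is the earlier exchange of one aryl group for another at the same saturated ring carbon, a 1.3-fold higher number from compound 1 to compound 2 (0.11 log units; within the scatter), which did not move the number beyond the scatter. A further aryl exchange at that carbon is therefore expected to leave the number about where it is, in no direction beyond the scatter, the expected step being no change at the digits printed from compound 2 to compound 3 (within the scatter). Compound 3 is accordingly estimated at 3700 nM, within a range from 1500 nM to 9000 nM.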

Compound 3, half-maximal inhibitory concentration: 10600 nM
Estimate against measurement, compound 3: 2.9-fold (0.46 log units) below; the measured number lies above the stated range.
By their numbers in this assay, from the lowest: compounds 1 and 2 (each within the scatter of the next); then compound 3.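

In this assay the aryl group on this saturated ring carbon proves not to be freely exchangeable: 3,5-difluorophenyl brings a 2.9-fold higher number from compound 2 to compound 3 (0.46 log units; beyond the scatter) and a 3.7-fold higher number from compound 1 to compound 3 (0.56 log units; beyond the scatter), so compound 3 is the weakest of the three. The earlier pair, carrying pyridin-3-yl and 4-bromophenyl, could not be told apart and gave no sign that the number at this position responds to the aryl group at all, though the response seen here is modest. No measurement given here accounts for this step.

As far as these compounds go, it remains open whether the step belongs to the fluorines themselves or to where they stand on the ring, which a comparison with 4-fluorophenyl could begin to separate. From the compounds shown here alone, it is also open whether a 4-methoxyphenyl or a 4-aminophenyl at this carbon would stay with compounds 1 and 2 or fall with compound 3.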